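Trimming a Piperidine to an Amine on a Weak Inhibitor

The source may report more compounds than this note shows. Statements on the series, on what has been measured and on what is new or still open speak of the compounds shown alone.

Of the compounds shown here, three sharing one core have been measured in a functional assay on SK-BR-3 cells (Homo sapiens) for activation, read by Western blot; on this read-out lower numbers stand for stronger inhibition and higher numbers for weaker inhibition. Among the compounds with values here, compound 1 `C=CC(=O)Nc1cc(N)nc(Sc2c(OC)nc(N3CCCCC3)nc2OC)n1` gives 5000 nM in this assay, the lowest of the three numbers so far. Compound 3 `C=CC(=O)Nc1cc(N)nc(Sc2c(OCC)nc(N3CCCCC3)nc2OCC)n1` differs from compound 1 in several places; in this assay compound 3 gives 10000 nM. This number sits within the usual scatter of that of compound 1, so no difference between the two can be claimed. Compound 2 `C=CC(=O)Nc1ccnc(Sc2c(OC)nc(N3CCCC3)nc2OC)n1` also differs from compound 1 in several places; in this assay compound 2 gives 25000 nM. Within the data shown here, that number lies higher than the one of compound 1 by a margin beyond the scatter.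

Compound 4 `C=CC(=O)Nc1cc(N)nc(Sc2c(OC)nc(N)nc2OC)n1` has not yet been measured. It differs from compound 1 in a single place: amino in place of piperidin-1-yl on an aromatic carbon of the core, between two ring nitrogen atoms, meta to two methoxy groups and para to a large group. The six heavy atoms of the piperidin-1-yl give way to a single nitrogen that brings one hydrogen-bond donor. Among the measured compounds shown here, no measured pair shows this change, so any expectation is loose. The step from compound 1 to compound 4 is expected to be a 2.0-fold higher number from compound 1 to compound 4 (0.30 log units; within the scatter), leaning toward a weaker compound. Compound 4 is therefore estimated at 10000 nM, with a range from 3000 nM to 40000 nM.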

Compound 4, half-maximal inhibitory concentration: 7500 nM
Compound 4: the middle estimate sits 1.3-fold (0.12 log units) above what was measured; the measured number falls inside the stated range.
By their numbers in this assay, from the lowest: compounds 1, 4 and 3 (each within the scatter of the next); then compound 2.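

Within the data shown here, putting amino in place of piperidin-1-yl on the shared core gives, in this assay, a 1.5-fold higher number from compound 1 to compound 4 (0.18 log units; within the scatter) and this is the first change at this position that can be read on its own, since the earlier compounds all differ from one another in several places. The two numbers lie within the usual scatter, so no difference between compound 1 and compound 4 can be claimed, even though the six-membered ring and its six heavy atoms are gone and a hydrogen-bond donor has come in. At this position, then, the piperidin-1-yl ring of compound 1 is not shown to matter for this weak inhibition, and nothing available explains why the swap leaves no measurable mark.

As far as these compounds go, whether a morpholine ring, a dimethylamino group or a longer chain such as butylamino at this position would give a number beyond the scatter stays open, in either direction. Compound 2 and compound 3 each differ from compound 1 in several places, so the separate contributions of their changes elsewhere on the core cannot be read.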